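Methylamino to dimethylamino: working notes on compound 3

This account rests on a few compounds, and the source may have more. Where it says the series, first, only, none or still open, it means among the compounds named here.

In an ADME assay on Vero cells (Chlorocebus sabaeus) for cytotoxicity, with a stated time of 5 days (on this read-out higher numbers stand for weaker inhibition and lower numbers for stronger inhibition), compound 1 `CN(C)c1nc(N)nc2c1ncn2[C@H]1C[C@H](N=[N+]=[N-])[C@@H](CO)O1` reads > 100000 nM as a limit of the assay. Compound 2 `CNc1nc(Cl)nc2c1ncn2[C@H]1C[C@H](N=[N+]=[N-])[C@@H](CO)O1` reads > 100000 nM as a limit too, so it has no number to stand on. Compound 3 `CN(C)c1nc(Cl)nc2c1ncn2[C@H]1C[C@H](N=[N+]=[N-])[C@@H](CO)O1` follows from compound 2 through methyl in place of hydrogen on a nitrogen on an aromatic ring in the methylamino to dimethylamino change, methyl in place of hydrogen on a nitrogen on an aromatic ring. No measured step sizes this change, and the expectation rests only on the limit of > 100000 nM in this assay, at which 2 of the 2 values shown sit, in this series. The expected a number no higher from compound 2 to compound 3 (the limit leaves the size open) stays within the scatter in this assay with no direction. For compound 3 the estimate is 100000 nM with an expected range from 40000 nM to 200000 nM in all likelihood.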

Compound 3, half-maximal inhibitory concentration: > 100000 nM
Compound 3 ended at the assay's limit; the forecaster's own chance of this, stated with the estimate: 85%; the middle value sits exactly at the limit.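

In this assay compound 3 gives > 100000 nM, a limit of the assay, so no new step can be read between compound 3 and either compound 1 or compound 2. The compounds shown leave open whether either change alters cytotoxicity at all.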